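Varying the Basic Amine Tail of an Anilinoquinazoline Series

The compounds below may be only part of what the source reports. "The series", "measured", "known", "first", "only" and "open" are said of these compounds alone.

Measured compounds:
- Compound 1, `COc1cc2c(Nc3ccc(C#N)cc3)ncnc2cc1OCCCN1CCCC1`, 21800 nM
- Compound 2, `COc1cc2c(Nc3ccc(C#N)cc3)ncnc2cc1OCCCN1CCC(C)CC1`, 32300 nM
- Compound 3, `COc1cc2c(Nc3ccc(C#N)cc3)ncnc2cc1OCCCN1CCC(N(C)C)CC1`, 42400 nM

All three share one core and differ only in the amine at the end of the chain. In a functional assay on A549 cells (Homo sapiens) for antiproliferative activity, read by MTT assay, with a stated time of 72 h (on this read-out lower numbers stand for stronger inhibition and higher numbers for weaker inhibition), compound 3 gives the highest of the three numbers, but its steps to the others, a 1.9-fold higher number from compound 1 to compound 3 (0.29 log units; within the scatter) and a 1.3-fold higher number from compound 2 to compound 3 (0.12 log units; within the scatter), both lie within the scatter, so no ordering among the three can be claimed. The step of a 1.5-fold higher number from compound 1 to compound 2 (0.17 log units; within the scatter) is likewise within the scatter.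

Compound 4, `COc1cc2c(Nc3ccc(C#N)cc3)ncnc2cc1OCCCN1CCN(c2ccncc2)CC1`, is not yet measured. It differs from compound 3 by 4-(pyridin-4-yl)piperazin-1-yl in place of 4-(dimethylamino)piperidin-1-yl on a saturated chain carbon, three bonds along the chain from an oxygen on an aromatic ring. Every measured step at this same position left the number essentially unchanged, which suggests that the amine end of the chain is tolerant of variation, although the group entering here is larger than any tried so far. The expectation is therefore no step beyond the scatter, a 1.2-fold lower number from compound 3 to compound 4 (0.08 log units; within the scatter), with the uncertainty widened for the untried ring. Compound 4 is estimated at 35000 nM in this assay, within a range from 12000 nM to 110000 nM.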

Compound 4, half-maximal inhibitory concentration: 25500 nM
Compound 4: the middle estimate sits 1.4-fold (0.14 log units) above what was measured, within the range that was stated.
By their numbers in this assay, from the lowest: compounds 1, 4, 2 and 3 (each within the scatter of the next).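

Even the larger 4-(pyridin-4-yl)piperazin-1-yl, which brings an aromatic ring to the chain end and has 12 heavy atoms against 9 in the group it replaces, gives only small steps in this assay (a 1.7-fold lower number from compound 3 to compound 4 (0.22 log units; within the scatter); a 1.3-fold lower number from compound 2 to compound 4 (0.10 log units; within the scatter); a 1.2-fold higher number from compound 1 to compound 4 (0.07 log units; within the scatter)). The tolerance seen among the simple amines at this place, on a saturated chain carbon, three bonds along the chain from an oxygen on an aromatic ring, therefore extends to a two-ring group, and all four compounds remain within the scatter of the next. No measurement is available that would explain this tolerance.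

Still open, going by these compounds, is whether a chain ending in a morpholine or a carboxylic acid, or a longer chain, would behave the same way. Also open, on these data alone, is whether a chloro group in place of the nitrile would give a larger step than any change at the chain end.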